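Swapping Chloro for Nitro: Expected Inhibition of Paw Edema

A few compounds are considered here, and "the series" means these few. Any claim that something is new, unique, unknown or untested is made for them only; others in the source may bear on it.

The measured compounds and their values:
compound 1, `Cc1cc(=O)oc2cc(OC(=O)CNc3ccccc3[N+](=O)[O-])ccc12`, 15.2%
compound 2, `Cc1cc(=O)oc2cc(OC(=O)CNc3ccccc3Cl)ccc12`, 23.7%
compound 3, `Cc1cc(=O)oc2cc(OC(=O)CNc3ccc(Cl)cc3)ccc12`, 16.1%

All three share one core and differ only in the ring carried on the amine nitrogen. In a functional assay on the whole organism (strain Wistar albino) for inhibition, with Rattus norvegicus as the target, read by paw edema, with stated times of 30 min and 4 h, at a dose of 20 mg/kg by the oral route (a lower number here means less inhibition, a higher number more inhibition at the dose given (going by the name of the read-out)), compound 2 gives 23.7%. Compound 1 differs from compound 2 by nitro in place of chloro on an aromatic carbon, and this gave the step of a number 8.5 percentage points lower from compound 2 to compound 1 (within the scatter). Compound 3 differs from compound 2 by 4-chlorophenyl in place of 2-chlorophenyl on an amine nitrogen, which gave the step of a number 7.6 percentage points lower from compound 2 to compound 3 (within the scatter). Compound 3 and compound 1 are close to one another in this assay, so no order between them can be read from these numbers.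

Compound 4, `Cc1cc(=O)oc2cc(OC(=O)CNc3ccc([N+](=O)[O-])cc3)ccc12`, has not yet been measured. It differs from compound 3 by nitro in place of chloro on an aromatic carbon. Among the compounds with values here, this is the same kind of change as the one from compound 2 to compound 1, though not the same: in compound 1 the nitro stands ortho to a large group, whereas in compound 4 it stands para to a large group.

A small lowering is expected from compound 3 to compound 4, of about a number 6.1 percentage points lower from compound 3 to compound 4 (within the scatter), because the step of a number 8.5 percentage points lower from compound 2 to compound 1 (within the scatter) stayed within the scatter. Within the data shown here, with only one earlier example, the estimate carries wide uncertainty. Compound 4 is thus expected to give about 10% in this assay, most likely falling between 2% and 19%.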

Compound 4, a percentage reported as inhibition, in the whole organism at one dose (the size of the read-out at that dose, not a potency): 23.7%
The estimate for compound 4 lay 13.7 percentage points below the measured number; the measured number lies above the stated range.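

In this assay, the new pair gives a number 7.6 percentage points higher from compound 3 to compound 4 (within the scatter), a step that on its own is too small to read as a real change. Set beside the earlier pair, however, the same swap of chloro for nitro went in opposite directions, so a result seen with this change in one pair could not be carried over to the other as a fixed increment: the same change on two cores in this assay, a number 8.5 percentage points lower (within the scatter) from compound 2 to compound 1 and a number 7.6 percentage points higher (within the scatter) from compound 3 to compound 4, 16.1 percentage points apart, beyond the scatter of two such steps. This does not show why the two steps part ways, since the two pairs also differ in where the swapped group stands on the ring, and two pairs are too few to separate that from anything else or to set a rule for the series.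

The compounds shown carry only chloro or nitro on this ring, which leaves open how other groups there, such as a methoxy group, an amine or a carboxylic acid, would behave in the same comparison. Also open, on these data alone, is whether the pattern would hold with a longer chain between the amine nitrogen and the ester carbonyl, or with both groups tested at a third place on the ring.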